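Trimming the aryl ether back to a hydroxymethyl group

The source may hold more compounds than are shown below. What is called first, only, known or untested is meant among the compounds shown, and "the series" means these compounds.

Of the compounds shown here, two sharing one core have been tested in a functional assay on A549 cells (Homo sapiens) for cytotoxicity, read by MTT assay, with a stated time of 48 h; on this read-out lower numbers stand for stronger inhibition and higher numbers for weaker inhibition. Compound 1 `COc1cc2c(cc1OC)CN(S(=O)(=O)c1ccc(-n3cc(COc4ccc(C=O)cc4)nn3)cc1)CC2` gives 31800 nM. Compound 2 `COc1cc2c(cc1OC)CN(S(=O)(=O)c1ccc(-n3cc(COc4cc(C=O)ccc4OC)nn3)cc1)CC2` gives 31900 nM; with the step of a 1.0-fold higher number from compound 1 to compound 2 (0.00 log units; within the scatter) within the scatter, compound 2 and compound 1 are indistinguishable on these numbers. Compound 3 `COc1cc2c(cc1OC)CN(S(=O)(=O)c1ccc(-n3cc(CO)nn3)cc1)CC2` has not been measured. It differs from compound 2 by hydrogen in place of 5-formyl-2-methoxyphenyl on an oxygen on a saturated carbon; cut one bond further out, the change reads 5-formyl-2-methoxyphenoxy to hydroxy. Among the measured compounds shown here, the only measured step, between compound 1 and compound 2, swaps one aryl ring for another and bears only loosely on this removal; nothing measured shows what losing the ring altogether does. With both measured compounds weak and no guide for direction, the expected step is a 1.3-fold higher number from compound 2 to compound 3 (0.10 log units; within the scatter), modest at most. Compound 3 is therefore expected to give 40000 nM, in a range of 15000 nM to 110000 nM, with a fair chance the assay reports only a limit.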

Compound 3, half-maximal inhibitory concentration: 41000 nM
Estimate against measurement, compound 3: 1.0-fold (0.01 log units) below, and the stated range covers the measured number.
By their numbers in this assay, from the lowest: compounds 1, 2 and 3 (each within the scatter of the next).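

In this assay, taking the whole aryl group off the oxygen on a saturated carbon leaves the read-out within the scatter, with a 1.3-fold higher number from compound 2 to compound 3 (0.11 log units; within the scatter) and a 1.3-fold higher number from compound 1 to compound 3 (0.11 log units; within the scatter). Among the compounds shown here, the earlier pair showed only that one aryl group could stand in for another, whereas compound 3 shows that neither the 5-formyl-2-methoxyphenyl group nor the 4-formylphenyl group is needed to keep the number where it stands, and the simple hydroxymethyl group serves as well. No supporting evidence bears on why this position tolerates so large a removal.

From the compounds shown here alone, what remains open is whether any group at this position can move the number beyond the scatter, as all three compounds sit within it. An amine or a carboxylic acid in place of the hydroxy group, or a longer chain ending in hydroxy, would test this, while the shared core stays unvaried across these compounds.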